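Extending the hydroxyalkyl chain of a sulfonamide acid

The compounds below may be only part of what the source reports. "The series", "measured", "known", "first", "only" and "open" are said of these compounds alone.

Of the compounds shown here, three have been measured in an assay on HEK293 cells for inhibition of prostaglandin E2 receptor EP2 subtype (Rattus norvegicus); a lower number here means a stronger inhibitor, a higher number a weaker inhibitor. Compound 1 `CCCCc1ccc(CN(Cc2ccccc2OCC(=O)O)S(C)(=O)=O)cc1` gives 3200 nM in this assay. Compound 2 `CC(C)(C)c1ccc(CN(Cc2cccc(CCC(=O)O)c2)S(=O)(=O)c2ccccn2)cc1` gives 52 nM. Compound 3 `CCCCC(O)c1ccc(CN(CCCCCCC(=O)O)S(C)(=O)=O)cc1` gives 502 nM, which places it second highest among the three numbers: the gap to compound 1, whose number is higher, lies beyond the scatter, and so does the larger gap to compound 2, whose number is lower. Among the measured compounds shown here, no two of these measured compounds differ in a single place, so no isolated step between measured values can be read from them.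

Compound 4 `CCCCCC(O)c1ccc(CN(CCCCCCC(=O)O)S(C)(=O)=O)cc1` has not yet been measured. It differs from compound 3 by one change only: methyl in place of hydrogen on a saturated chain carbon, five bonds along the chain from an aromatic carbon and an oxygen on a saturated carbon. The rest of the structure is the same.

For the measured compounds named here, since the measured set holds no step of this kind, the expectation rests on the small size of the change, a single carbon added to a saturated chain far from the acid. The step of a 1.2-fold lower number from compound 3 to compound 4 (0.08 log units; within the scatter) is expected to be small, in either direction, and not beyond the scatter. Compound 4 is therefore expected to give about 420 nM in this assay, with a likely range from 160 nM to 1100 nM.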

Compound 4, half-maximal inhibitory concentration: 93 nM
Estimate against measurement, compound 4: 4.5-fold (0.65 log units) above; the whole stated range lies above it.
By their numbers in this assay, from the lowest: compounds 2 and 4 (each within the scatter of the next); then compound 3; then compound 1.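

In this assay, methyl in place of hydrogen on a saturated chain carbon, five bonds along the chain from an aromatic carbon and an oxygen on a saturated carbon, gives a 5.4-fold lower number from compound 3 to compound 4 (0.73 log units; beyond the scatter). Among the compounds shown here, the earlier compounds differed in several places at once, so this is the first step that isolates a single change, and it shows that the far end of this chain is not indifferent to its length: one added carbon, with no ring, no hydrogen-bond donor or acceptor and no net charge, moves the number beyond the scatter. No measurement of any property bears on this result, and the reason for the step remains unknown.

The compounds shown leave open whether a longer chain at this place would lower the number further or raise it again, as a single step fixes no trend. They also leave open whether a terminal phenyl ring or a branched chain would be accepted here, and whether the same added carbon would give a step of similar size on the core of compound 2.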